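A few compounds are considered here, and "the series" means these few. Any claim that something is new, unique, unknown or untested is made for them only; others in the source may bear on it.

Three compounds have been measured in an ADME assay on MT4 cells (Homo sapiens) for cytotoxicity, read by MTT assay; on this read-out higher numbers stand for lower toxicity in this test and lower numbers for higher toxicity in this test:

Compound 1, `Cc1ccc(CNC(=O)c2[nH]c3ccc(Cl)cc3c2S(=O)(=O)c2cc(C)cc(C)c2)cc1`: 21200 nM
Compound 2, `COc1ccc(CNC(=O)c2[nH]c3ccc(Cl)cc3c2S(=O)(=O)c2cc(C)cc(C)c2)cc1`: 39900 nM
Compound 3, `Cc1cc(C)cc(S(=O)(=O)c2c(C(=O)NCc3ccc(F)cc3)[nH]c3ccc(Cl)cc23)c1`: > 53000 nM

For compound 3 the value > 53000 nM is only a limit of the test, not a number. The steps of an at least 2.5-fold higher number from compound 1 to compound 3 (0.39 log units; beyond the scatter) and an at least 1.3-fold higher number from compound 2 to compound 3 (0.12 log units; that floor lies within the scatter) place compound 3 at the low-toxicity edge of this small set. Compound 4, `Cc1cc(C)cc(CNC(=O)c2[nH]c3ccc(Cl)cc3c2S(=O)(=O)c2cc(C)cc(C)c2)c1`, differs from compound 3 in one place: 3,5-dimethylphenyl in place of 4-fluorophenyl on a saturated chain carbon bound to an amide-type nitrogen. Among the compounds with values here, the one measured step that bears on it is an at least 2.5-fold higher number from compound 1 to compound 3 (0.39 log units; beyond the scatter), where methyl became fluoro on an aromatic carbon and the number rose; the change to compound 4 runs the other way, towards methyl groups. Compound 4 is therefore expected to give a lower number, a modest step of an at least 2.1-fold lower number from compound 3 to compound 4 (0.32 log units; beyond the scatter). Compound 4 is estimated at 25000 nM, within 10000 nM to 60000 nM.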

Compound 4, half-maximal cytotoxic concentration: > 51900 nM
Compound 4: a limit, no number (the forecaster's own chance of this, stated with the estimate: 30%); at least 2.0-fold (0.31 log units) between middle value and limit.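

In this assay compound 4 also ends at a limit of the test, > 51900 nM, not a number. Setting 3,5-dimethylphenyl in place of 4-methylphenyl gives an at least 2.4-fold higher number from compound 1 to compound 4 (0.38 log units; beyond the scatter), so a ring carrying methyl groups at this place need not give the lower number, and fluoro is not needed to reach a limit. In place of 4-methoxyphenyl, the same group gives an at least 1.3-fold higher number from compound 2 to compound 4 (0.11 log units; that floor lies within the scatter), while the step between compound 3 and compound 4 cannot be read, since both values are limits. Where the true values of these two compounds lie remains open. So does how an amine or a carboxylic acid on the ring would read at this place.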